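The source may hold more compounds than are shown below. What is called first, only, known or untested is meant among the compounds shown, and "the series" means these compounds.

Of the compounds shown here, three that share one core have been tested in an in vitro functional assay on HEK ts201 cells for antagonist activity at Neuronal acetylcholine receptor; alpha4/beta2 (Homo sapiens), read by fluorescence and calcium flux; on this read-out lower numbers stand for stronger inhibition and higher numbers for weaker inhibition. Compound 1 `COc1ccc(OCCCCCN2CCCC(COC(=O)c3ccccc3N3C(=O)CC(C)C3=O)C2)cc1OC` gives 8320 nM in this assay. Compound 2 `O=C(OCC1CCCN(CCCc2ccccc2)C1)c1ccccc1N1C(=O)c2ccccc2C1=O` gives 5010 nM, and compound 3 `O=C(OCC1CCCN(CCCc2ccccc2)C1)c1ccccc1N1C(=O)CC(Cc2ccc(Cl)cc2)C1=O` gives 10700 nM. The number for compound 1 sits close to that of compound 3 and to that of compound 2, and all three lie within the usual scatter of one another, so none of them stands apart. Compound 4 `CC1CC(=O)N(c2ccccc2C(=O)OCC2CCCN(CCCCCOc3ccc(Cl)c(Cl)c3)C2)C1=O` differs from compound 1 in one place: 3,4-dichlorophenyl in place of 3,4-dimethoxyphenyl on an oxygen on a saturated carbon. Within the data shown here, no measured pair shows this exchange, so nothing in the data tells its effect in this assay. The step of a 1.2-fold lower number from compound 1 to compound 4 (0.08 log units; within the scatter) is therefore expected to be small, in no fixed direction, and not beyond the scatter. The estimate for compound 4 in this assay is 7000 nM, with a range from 2500 nM to 20000 nM.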

Compound 4, half-maximal inhibitory concentration: 17400 nM
Compound 4: the middle estimate sits 2.5-fold (0.40 log units) below what was measured, within the range that was stated.
By their numbers in this assay, from the lowest: compounds 2, 1, 3 and 4 (each within the scatter of the next, the first and the last beyond it).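

In this assay, 3,4-dichlorophenyl in place of 3,4-dimethoxyphenyl on this oxygen gives a 2.1-fold higher number from compound 1 to compound 4 (0.32 log units; beyond the scatter) and so weakens inhibition. Among these compounds, this is the first single-place change that can be read here, and it shows that the read-out responds to the group at this position, though only modestly. Nothing available explains the step. On these data alone, whether plain phenyl, or a ring carrying one methoxy group or one chlorine, would behave like compound 1 or compound 4 remains open. So does whether a longer chain would change the size of this step.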